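A Cyclohexyl Amide Tested Against Fibroblast Growth

This account rests on a few compounds, and the source may have more. Where it says the series, first, only, none or still open, it means among the compounds named here.

Compound 1 `O=C(CN1CCN(c2cc3c(cc2F)c(=O)c(C(=O)O)cn3C2CC2)CC1)Nc1ccccc1` and compound 2 `COc1ccc(NC(=O)CN2CCN(c3cc4c(cc3F)c(=O)c(C(=O)O)cn4C3CC3)CC2)cc1` were both tested in an ADME assay on WI-38 cells (Homo sapiens) for antiproliferative activity, read by BrdU incorporation, with a stated time of 24 h; a higher number here means a weaker inhibitor, a lower number a stronger inhibitor. In this assay compound 1 gives only a limit, > 100000 nM. Compound 2 likewise gives only a limit, > 100000 nM. The step that the two limits leave unreadable from compound 1 to compound 2 cannot be read, since both values sit at the same ceiling (the limit of > 100000 nM in this assay, at which 2 of the 2 values shown sit). Compound 3 `O=C(CN1CCN(c2cc3c(cc2F)c(=O)c(C(=O)O)cn3C2CC2)CC1)NC1CCCCC1` differs from compound 2 by cyclohexyl in place of 4-methoxyphenyl on an amide-type nitrogen. Among the measured compounds shown here, no measured step shows how such a change acts here. With compound 2 at a limit, compound 3 is expected to stay near it, a step that the limit leaves unreadable from compound 2 to compound 3. Compound 3 is estimated at 150000 nM, between 50000 nM and 500000 nM.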

Compound 3, half-maximal inhibitory concentration: > 100000 nM
Compound 3: only a limit was reported; the forecaster's own chance of this, stated with the estimate: 85%; the middle value does not contradict the limit.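

Among the compounds shown here, no step among compound 1, compound 2 and compound 3 can be read in this assay, since each gives only a limit: the limit of > 100000 nM in this assay, at which 3 of the 3 values shown sit. These compounds leave open whether any group on the amide-type nitrogen would give a readable value in this assay.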